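Swapping 2,4,6-trichlorophenyl for 3-fluorophenyl in an antiproliferative series

The compounds below may be only part of what the source reports. "The series", "measured", "known", "first", "only" and "open" are said of these compounds alone.

In a functional assay on MCF7 cells (Homo sapiens) for antiproliferative activity, read by sulforhodamine B assay, with a stated time of 48 h (a lower number here means a stronger inhibitor, a higher number a weaker inhibitor), compound 1 `CCCN1CCN(c2ccc(S(=O)(=O)Oc3ccccc3OC)cc2)C1=O` gives 13000 nM, and compound 2 `CCCN1CCN(c2ccc(S(=O)(=O)Oc3cc(Cl)c(Cl)cc3Cl)cc2)C1=O` gives 13000 nM. Between these two the data show no change at the digits printed from compound 1 to compound 2 (within the scatter). Compound 3 `CCCN1CCN(c2ccc(S(=O)(=O)Oc3c(Cl)cc(Cl)cc3Cl)cc2)C1=O` has no number, only a limit of the assay, > 100000 nM. The measured steps that reach it are an at least 7.6-fold higher number from compound 1 to compound 3 (0.88 log units; beyond the scatter) and an at least 7.6-fold higher number from compound 2 to compound 3 (0.88 log units; beyond the scatter).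

Compound 4 `CCCN1CCN(c2ccc(S(=O)(=O)Oc3cccc(F)c3)cc2)C1=O` has 3-fluorophenyl in place of 2,4,6-trichlorophenyl on an oxygen whose other neighbour is the sulfonyl sulfur: 3-fluorophenyl in place of 2,4,6-trichlorophenyl on an oxygen. The fluorinated group itself has not been measured in this core, so the comparison has to come from the other groups on the same oxygen. Both 2-methoxyphenyl in compound 1, at 13000 nM, and 2,4,5-trichlorophenyl in compound 2, at 13000 nM, give a measurable number. Only the 2,4,6-trichlorophenyl of compound 3 reaches the limit. Compound 4 is therefore expected to read like the first two rather than like compound 3, in the opposite direction to the two steps that reach the limit and of at least similar size. The expected change is an at least 6.6-fold lower number from compound 3 to compound 4 (0.82 log units; beyond the scatter). In this assay the estimate for compound 4 is 15000 nM, with an expected range of 4000 nM to 60000 nM.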

Compound 4, half-maximal inhibitory concentration: 24000 nM
Beside the measured number, compound 4's estimate is 1.6-fold (0.20 log units) below it, and the stated range covers the measured number.
By their numbers in this assay, from the lowest: compounds 1, 2 and 4 (each within the scatter of the next). At a limit, above all of these: compound 3.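

In this assay, 3-fluorophenyl on the oxygen whose other neighbour is the sulfonyl sulfur gives a measurable number where 2,4,6-trichlorophenyl does not, with an at least 4.1-fold lower number from compound 3 to compound 4 (0.61 log units; beyond the scatter). Set against the other two measured groups on that oxygen, the data show a 1.8-fold higher number from compound 2 to compound 4 (0.27 log units; within the scatter) and a 1.8-fold higher number from compound 1 to compound 4 (0.27 log units; within the scatter), so a third, differently substituted phenyl group reads alike in this position. Among the four compounds, compound 3 alone stands apart, and its reading is only a limit of the assay: the limit of > 100000 nM in this assay, at which 1 of the 4 values shown sits.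

The compounds shown leave open what separates 2,4,6-trichlorophenyl from 2,4,5-trichlorophenyl, two groups with the same atoms that part by at least the step already printed for them. From the compounds shown here alone, it also remains open whether an unsubstituted phenyl, a 2,6-dichlorophenyl, or a phenyl carrying an amine or a carboxylic acid on this oxygen would read like compounds 1, 2 and 4 or like compound 3.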